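Cytotoxicity Limits for Three Compounds and an Untested Fourth

This account rests on a few compounds, and the source may have more. Where it says the series, first, only, none or still open, it means among the compounds named here.

The study reports three compounds in an ADME assay on A-431 cells (Homo sapiens) for cytotoxicity, with a stated time of 48 h; on this read-out lower numbers stand for stronger inhibition and higher numbers for weaker inhibition. Compound 1 `O=[N+]([O-])c1cc(CSc2nnc(-c3ccccc3)n2-c2ccc(Cl)c(Cl)c2)cc([N+](=O)[O-])c1` gives only a limit of > 30000 nM in this assay. Compound 2 `O=[N+]([O-])c1cc(CSc2nnc(-c3ccc(Cl)cc3)n2Cc2ccccc2)cc([N+](=O)[O-])c1` likewise stops at a limit of > 30000 nM. Compound 3 `O=[N+]([O-])c1cc(CSc2nnc(C3CCCCC3)n2Cc2ccccc2)cc(C(F)(F)F)c1` also reaches only a limit of > 30000 nM. No numbered value appears for any of them; the whole body of evidence amounts to the limit of > 30000 nM in this assay, at which 3 of the 3 values shown sit. Compound 3 therefore stands exactly where the other two stand, at the limit, and no ordering among the three can be drawn from these results.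

Compound 4 `O=[N+]([O-])c1cc(CSc2nnc(-c3ccc(Cl)cc3)n2Cc2ccccc2)cc(C(F)(F)F)c1` has not yet been tested. It differs from compound 3 by 4-chlorophenyl in place of cyclohexyl on an aromatic carbon. Among the compounds with values here, no measured pair of compounds differs in a single place, so no step size has been observed. Compound 2, which also carries a 4-chlorophenyl group, gives only a limit of > 30000 nM. The step from compound 3 to compound 4 is expected to be a step that the limit leaves unreadable from compound 3 to compound 4, that is, none beyond the usual scatter. Compound 4 is accordingly estimated at 60000 nM, within a range of 30000 nM to 200000 nM, and is most likely to be reported again only as a limit.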

Compound 4, half-maximal inhibitory concentration: > 30000 nM
Compound 4: only a limit was reported (the forecaster's own chance of this, stated with the estimate: 85%); the middle value lies beyond the limit too.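

The steps from compound 3 to compound 4 and from compound 2 to compound 4 cannot be read, because both ends of each step are limits: the limit of > 30000 nM in this assay, at which 4 of the 4 values shown sit.

The compounds shown leave open whether 4-chlorophenyl in place of cyclohexyl, or trifluoromethyl in place of nitro, changes the read-out at all, and where any of the four compounds would give an actual number.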